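A few compounds are considered here, and "the series" means these few. Any claim that something is new, unique, unknown or untested is made for them only; others in the source may bear on it.

Measured so far:
- compound 1, `Cc1ccccc1C(=O)N(NC(=O)c1ccccc1)C(C)(C)C`: 224 nM
- compound 2, `CCc1ccccc1C(=O)N(NC(=O)c1ccccc1)C(C)(C)C`: 589 nM
- compound 3, `CCc1ccc(C(=O)NN(C(=O)c2ccccc2Cl)C(C)(C)C)cc1`: 5.75 nM

All three were run in an assay on cells for agonist activity at ecdysone receptor (Bombyx mori), read by a luciferase reporter, with a stated time of 24 h; on this read-out lower numbers stand for an effect already at smaller amounts and higher numbers for an effect only at larger amounts of compound. Compound 3 gives the lowest number of the three; its gap to compound 1 and to compound 2 lies beyond the scatter in both cases. The difference between the core of compound 3 and the core of compound 1 is not broken down here.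

One change within the set is repeated. From compound 1 to compound 2 the change is methyl in place of hydrogen on a saturated chain carbon bound to an aromatic carbon, and it made a 2.6-fold higher number from compound 1 to compound 2 (0.42 log units; beyond the scatter) in this assay. The unmeasured compound 4, `CCCc1ccc(C(=O)NN(C(=O)c2ccccc2Cl)C(C)(C)C)cc1`, is related to compound 3 by methyl in place of hydrogen on a saturated chain carbon, two bonds along the chain from an aromatic carbon. This is the same kind of change, but the place is not the same: in the earlier pair the saturated chain carbon is bound to an aromatic carbon, here it is two bonds along the chain from an aromatic carbon, so the pair reads ethyl to propyl rather than methyl to ethyl.

Resting on the one earlier step of a 2.6-fold higher number from compound 1 to compound 2 (0.42 log units; beyond the scatter), a modest rise in the number is expected for compound 4, giving an estimated 2.1-fold higher number from compound 3 to compound 4 (0.32 log units; beyond the scatter). The estimate for compound 4 in this assay is therefore 12 nM, between 4 nM and 40 nM.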

Compound 4, half-maximal effective concentration: 9.12 nM
Compound 4: middle estimate off by 1.3-fold (0.12 log units), on the high side; measured number inside the range.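

In this assay, adding the methyl on the core of compound 3 gives a 1.6-fold higher number from compound 3 to compound 4 (0.20 log units; within the scatter), so the ethyl to propyl change leaves the number within the scatter. Set beside the earlier methyl to ethyl step, the size of the change does not separate the two cores: the same change on two cores in this assay, a 2.6-fold higher number (0.42 log units; beyond the scatter) from compound 1 to compound 2 and a 1.6-fold higher number (0.20 log units; within the scatter) from compound 3 to compound 4, 1.7-fold (0.22 log units) apart, within the scatter of two such steps

Among these compounds, this supports carrying the change between these two cores with a small expected step, but only one of the two steps lies beyond the scatter, each core contributes a single pair, and the place on the chain differs between the pairs, so it does not show that the two steps are identical or that the result extends to other cores.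

The compounds shown leave open whether a longer chain such as butyl, or a branched chain such as isopropyl, in place of the propyl of compound 4 would stay within the scatter of compound 3. Also open, as far as these compounds go, is what an ether oxygen or an amine in that chain would do.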